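A few compounds are considered here, and "the series" means these few. Any claim that something is new, unique, unknown or untested is made for them only; others in the source may bear on it.

Measured compounds:
- compound 1 `CC(C)(C)OC(=O)Nc1ncc(C(Oc2ccc(Cc3ccccc3)cc2)c2ccc(Cl)cc2)s1`: > 50000 nM in an ADME assay on HepG2 2.2.15 cells (Homo sapiens) for cytotoxicity; on this read-out lower numbers stand for higher toxicity in this test and higher numbers for lower toxicity in this test
- compound 2 `O=C(Nc1ncc(C(Oc2ccc3cc(Br)ccc3c2)c2ccc(Cl)cc2)s1)C1CC1`: "not toxic" (no number reported) in this assay

Compound 1 carries a tert-butyl carbamate on the shared core, and in this assay its result is a limit of the measurement, > 50000 nM, not a number. Compound 2 carries a cyclopropylcarbonyl amide on the same core and is reported in this assay only as "not toxic" (no number reported), again without a number. Where compound 2 stands can therefore only be said in relation to the one limit shown, (the limit of > 50000 nM in this assay, at which 1 of the 2 values shown sits), which is where the single numerical entry of the pair sits; compound 2 gives no value that could be placed against it.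

Compound 3 `O=C(Nc1ncc(C(Oc2ccc3cc(Br)ccc3c2)c2ccc(Cl)cc2)s1)c1ccc(F)cc1Br` differs from compound 2 by 2-bromo-4-fluorophenyl in place of cyclopropyl on a carbonyl carbon. Within the data shown here, no step between measured compounds is known, so there is nothing to scale this change against. Given that both measured compounds reach no number in this assay, compound 3 is expected to behave alike, with no step beyond the scatter and most likely another limit. Compound 3 is estimated at 50000 nM, within 15000 nM to 100000 nM.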

Compound 3, half-maximal cytotoxic concentration: > 50000 nM
Compound 3: no number, only a limit (the forecaster's own chance of this, stated with the estimate: 70%); the middle value lies on the limit itself.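

In this assay compound 3 gives > 50000 nM, which is a limit and not a number. Compound 2 has no number either, so no step can be read between compound 2 and compound 3. The compounds shown leave open at what concentration, if any, each would turn cytotoxic, and whether swapping cyclopropyl for 2-bromo-4-fluorophenyl changes that: the limit of > 50000 nM in this assay, at which 2 of the 3 values shown sit.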